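Chain extension between aryl ether and piperidine

The source may hold more compounds than are shown below. What is called first, only, known or untested is meant among the compounds shown, and "the series" means these compounds.

Compound 1: `COc1cc(/C=C/C(=O)Nc2ccccc2)ccc1OCCCCN(C)C`; a physicochemical assay for lipophilicity, using the shake flask method, measured as octanol-water partition, at pH 7.4 (a higher number here means a more lipophilic compound, a lower number a more polar compound), 1.57
Compound 2: `COc1cc(/C=C/C(=O)Nc2ccccc2)ccc1OCCCCN1CCCCC1`; in this assay compound 2 gives 1.61

Compound 2 stands highest of the two measured numbers, with compound 1 nearest; the step of a number 0.04 log units higher from compound 1 to compound 2 (within the scatter) is within the scatter, so no order between them can be claimed. Compound 3, `COc1cc(/C=C/C(=O)Nc2ccccc2)ccc1OCCCCCCN1CCCCC1`, differs from compound 2 by 2-(piperidin-1-yl)ethyl in place of piperidin-1-yl on a saturated chain carbon, four bonds along the chain from an oxygen on an aromatic ring. For the measured compounds named here, no measured step lengthens this chain; the only step available, a number 0.04 log units higher from compound 1 to compound 2 (within the scatter), exchanges one amine for another and stayed within the scatter, so it offers no direct guide to a longer chain. An added chain of this kind is commonly accompanied by a rise in this assay, so a step beyond the scatter upward is expected. The estimated step is a number 0.79 log units higher from compound 2 to compound 3 (beyond the scatter). For compound 3 the expected value in this assay is 2.4, with a range from 1.9 to 3.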

Compound 3, partition coefficient: 1.77
Compound 3: the middle estimate sits 0.63 log units above what was measured, outside the stated range (below it).
By their numbers in this assay, from the lowest: compounds 1, 2 and 3 (each within the scatter of the next).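

Putting 2-(piperidin-1-yl)ethyl in place of piperidin-1-yl on a saturated chain carbon, four bonds along the chain from an oxygen on an aromatic ring, gives a number 0.16 log units higher from compound 2 to compound 3 (within the scatter) in this assay and so this lengthening of the chain, the only one shown, does not separate the two compounds. The exchange of dimethylamino for the same group gives a number 0.20 log units higher from compound 1 to compound 3 (within the scatter) and so, at this position, neither the amine exchange nor the longer chain yet gives a difference that this assay can resolve. Nothing measured here bears on why the numbers lie so close.

On these data alone, whether a still longer chain on the piperidine compound would move the number beyond the scatter remains open. So does whether a morpholine or a carboxylic acid at the end of the chain would do so.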